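Working notes: methyl to fluoro on compound 3

The source may hold more compounds than are shown below. What is called first, only, known or untested is meant among the compounds shown, and "the series" means these compounds.

compound 1 `COc1cc(C(=O)c2cn(-c3cccc(N)c3)cc2-c2cccc([N+](=O)[O-])c2)cc(OC)c1OC` gives 510 nM
compound 2 `COc1cc(C(=O)c2cn(-c3ccc(C)cc3)cc2-c2ccccc2[N+](=O)[O-])cc(OC)c1OC` gives 65 nM
compound 3 `COc1cc(C(=O)c2cn(-c3ccc(C)cc3)cc2-c2cccc([N+](=O)[O-])c2)cc(OC)c1OC` gives 210 nM

In a functional assay on MCF7 cells (Homo sapiens) for cytotoxicity, read by MTT assay, with a stated time of 96 h (on this read-out higher numbers stand for weaker inhibition and lower numbers for stronger inhibition), compound 3 holds the second highest of the three numbers (210 nM). Compound 4 `COc1cc(C(=O)c2cn(-c3ccc(F)cc3)cc2-c2cccc([N+](=O)[O-])c2)cc(OC)c1OC` carries fluoro in place of methyl on an aromatic carbon, para to a large group (fluoro in place of methyl on an aromatic carbon). For the measured compounds named here, no measured step makes this exchange. The closest evidence is a 2.4-fold lower number from compound 1 to compound 3 (0.39 log units; beyond the scatter), which changes the group on the aromatic nitrogen. The other measured step, a 3.2-fold higher number from compound 2 to compound 3 (0.51 log units; beyond the scatter), changes the nitrophenyl group instead. Both are modest, and neither gives a direction for this exchange, so no step beyond the scatter is expected in this assay. The estimated step is a 1.1-fold lower number from compound 3 to compound 4 (0.02 log units; within the scatter). Compound 4 is estimated at 200 nM, with an expected range of 90 nM to 450 nM.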

Compound 4, half-maximal inhibitory concentration: 440 nM
Compound 4: middle estimate off by 2.2-fold (0.34 log units), on the low side; the measured number falls inside the stated range.
By their numbers in this assay, from the lowest: compound 2; then compound 3; then compounds 4 and 1 (each within the scatter of the next).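

In this assay this position, para to a large group, is sensitive to a one-atom exchange: fluoro in place of methyl gives a 2.1-fold higher number from compound 3 to compound 4 (0.32 log units; beyond the scatter), the first step measured at this place. With a 1.2-fold lower number from compound 1 to compound 4 (0.06 log units; within the scatter), 4-fluorophenyl and 3-aminophenyl cannot be told apart on the 3-nitrophenyl background. Nothing at hand explains the shift.

Open, on these data alone, is whether chloro or methoxy at this place would read closer to methyl or to fluoro. Also open, as far as these compounds go, is whether the exchange from methyl to fluoro gives the same step alongside 2-nitrophenyl.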